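Swapping isopropylamino for ethyl(methyl)amino in compound 1

The source may report more compounds than this note shows. Statements on the series, on what has been measured and on what is new or still open speak of the compounds shown alone.

In a functional assay on T-24 cells (Homo sapiens) for antiproliferative activity, read by MTT assay, with a stated time of 72 h (on this read-out lower numbers stand for stronger inhibition and higher numbers for weaker inhibition), compound 1 `CC(C)NC(=N)NC(=N)Nc1ccc(C(F)(F)F)cc1` gives 4800 nM and compound 2 `CC(C)CNC(=N)NC(=N)Nc1ccc(F)c(F)c1` gives 42900 nM, so compound 1 holds the lowest number of the series. For compound 3 `CC(C)NC(=N)NC(=N)Nc1ccc(F)cc1` the result is a limit and not a number: > 50000 nM.

The next candidate, compound 4 `CCN(C)C(=N)NC(=N)Nc1ccc(C(F)(F)F)cc1`, has the same atoms as compound 1, joined differently: ethyl(methyl)amino in place of isopropylamino on a carbon with a double bond to nitrogen. In words, ethyl(methyl)amino stands in place of isopropylamino on a carbon with a double bond to nitrogen.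

Going by the values given here, only one measured step changes a single place, and it is a different place: an at least 10-fold higher number from compound 1 to compound 3 (1.01 log units; beyond the scatter). That large step, beyond the scatter, came with fluoro in place of trifluoromethyl on an aromatic carbon. Compound 4 keeps the trifluoromethyl group, so that step does not carry over to it. Among the compounds with values here, no measured pair tests the new change, which leaves the size of the step uncertain. The most reasonable expectation in this assay is therefore no step beyond the scatter, with more room towards weaker inhibition than stronger. The expected change is a 1.5-fold higher number from compound 1 to compound 4 (0.16 log units; within the scatter). For compound 4 the estimated value is 7000 nM, with an expected range of 2500 nM to 25000 nM.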

Compound 4, half-maximal inhibitory concentration: 5700 nM
Beside the measured number, compound 4's estimate is 1.2-fold (0.09 log units) above it; the measured number falls inside the stated range.
By their numbers in this assay, from the lowest: compounds 1 and 4 (each within the scatter of the next); then compound 2. At a limit, above all of these: compound 3.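

The swap of isopropylamino for ethyl(methyl)amino on a carbon with a double bond to nitrogen gives, in this assay, a 1.2-fold higher number from compound 1 to compound 4 (0.07 log units; within the scatter), so this exchange leaves the reading within the usual scatter. Going by these compounds alone, the earlier step concerned only the group on the aromatic carbon, so this is the first single-place comparison at this position. It also shows that the hydrogen-bond donor counted on isopropylamino, which ethyl(methyl)amino lacks, can be exchanged here with no difference beyond the scatter, although nothing measured here explains why the two numbers stay so close.

Both groups have the same number of heavy atoms, so the compounds shown do not reveal how much change this position accepts with a different size or kind of group, such as a simple dimethylamino, a longer chain such as hexylamino, or a ring such as piperidine. Going by these compounds, it also remains open whether ethyl(methyl)amino would give a similar result with fluoro rather than trifluoromethyl on the aromatic carbon, or whether a group such as a carboxylic acid at this position would be accepted.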